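A few compounds are considered here, and "the series" means these few. Any claim that something is new, unique, unknown or untested is made for them only; others in the source may bear on it.

Measured so far:
Compound 1, `CCCC[Te]c1ccc(C(C)N)cc1`, in a functional assay, read by spectrophotometry, with a stated time of 30 min (a lower number here means a stronger inhibitor, a higher number a weaker inhibitor), gives 12.1 ug/mL.
Compound 2, `CCCC[Te]c1ccc(C(C)NCc2ccccc2)cc1`, in this assay gives 11.4 ug/mL.

Among the compounds with values here, compound 2 holds the lower of the two numbers, yet the single step recorded, a 1.1-fold lower number from compound 1 to compound 2 (0.03 log units; within the scatter), leaves the two compounds indistinguishable. Compound 3, `CCCC[Te]c1ccc(C(C)NCC(C)C)cc1`, differs from compound 2 by isopropyl in place of phenyl on a saturated chain carbon bound to an amine nitrogen. Within the data shown here, the only measured step that bears on it is the change at the same amine nitrogen, a 1.1-fold lower number from compound 1 to compound 2 (0.03 log units; within the scatter), and that was within the scatter. Among the measured compounds shown here, no measured pair tests a phenyl-to-isopropyl exchange on that chain carbon, so the series is silent on this particular swap. With nothing pointing either way, the expected step of a 1.0-fold higher number from compound 2 to compound 3 (0.00 log units; within the scatter) in this assay is none beyond the scatter. Compound 3 is therefore estimated at 11.5 ug/mL, with a range from 6 ug/mL to 23 ug/mL. The width of that range reflects the absence of any directly comparable step rather than a sign of direction.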

Compound 3, half-maximal inhibitory concentration: 12.5 ug/mL
Estimate against measurement, compound 3: 1.1-fold (0.04 log units) below, and the stated range covers the measured number.
By their numbers in this assay, from the lowest: compounds 2, 1 and 3 (each within the scatter of the next).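

In this assay, isopropyl in place of phenyl on a saturated chain carbon bound to an amine nitrogen gives a 1.1-fold higher number from compound 2 to compound 3 (0.04 log units; within the scatter) and so stays within the scatter; the phenyl ring of compound 2 is therefore not required for a number of this size. Isobutyl in place of hydrogen on the amine nitrogen gives a 1.0-fold higher number from compound 1 to compound 3 (0.01 log units; within the scatter) and also stays within the scatter, so compound 1, compound 2 and compound 3 cannot be told apart in this assay, whether that nitrogen carries hydrogen, benzyl or isobutyl. No measurement on hand offers an explanation for this lack of separation.

As far as these compounds go, whether a carboxylic acid, an amide or a much longer chain on this nitrogen would give a step beyond the scatter remains open. Also open, from the compounds shown here alone, is whether a change in the shared core would shift the number where changes at this nitrogen have not.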